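Aryl swap on the core of compound 1

The source may hold more compounds than are shown below. What is called first, only, known or untested is meant among the compounds shown, and "the series" means these compounds.

Compound 1 `COc1ccc(C2OC(c3cc(OC)c(OC)c(OC)c3)=NN2C(C)=O)c(OC)c1` gives 92% in a functional assay on PC-3 cells (Homo sapiens) for antiproliferative activity, read by MTT assay, tested at 5 uM (a lower number here means a weaker effect, a higher number a stronger effect of the compound at the concentration tested), the highest of the three numbers, beyond the scatter from both others. Compound 2 `COc1cc(C(=O)N/N=C/c2cccc(F)c2)cc(OC)c1OC` gives 64.1% in this assay, and compound 3 `COc1cc(C(=O)N/N=C/c2c(Cl)cccc2Cl)cc(OC)c1OC` gives 52.1%. Among the compounds with values here, the only measured step, a number 12 percentage points lower from compound 2 to compound 3 (beyond the scatter), lies on a different core, so it bears only loosely on the change at hand. Compound 4 `COc1cc(C2=NN(C(C)=O)C(c3ccc(Cl)c(Cl)c3)O2)cc(OC)c1OC` keeps the core of compound 1 with 3,4-dichlorophenyl in place of 2,4-dimethoxyphenyl on a saturated ring carbon. Since that step went modestly downward and compound 1 already sits near the top of the read-out, a moderate decrease is expected, a number 17 percentage points lower from compound 1 to compound 4 (beyond the scatter). Compound 4 is estimated at 75%, with a range from 50% to 95%.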

Compound 4, a percentage reported as inhibition, at one concentration (the size of the read-out at that concentration, not a potency): 26.1%
The estimate for compound 4 lay 48.9 percentage points above the measured number, outside the stated range (below it).
By their numbers in this assay, from the lowest: compound 4; then compound 3; then compound 2; then compound 1.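

Changing the aryl group on the saturated ring carbon of the core of compound 1 moves the read-out in this assay strongly, with 3,4-dichlorophenyl in place of 2,4-dimethoxyphenyl giving a number 65.9 percentage points lower from compound 1 to compound 4 (beyond the scatter). The step on the other core, a number 12 percentage points lower from compound 2 to compound 3 (beyond the scatter), gave no sign of a change this large. Nothing measured here bears on why the read-out falls.

The swap changes both the substituents and their placement, so the compounds shown do not separate the two. Open, going by these compounds, is how 2,4-dichlorophenyl, 3,4-dimethoxyphenyl or a phenyl carrying a dimethylamino group would read on this core.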